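A few compounds are considered here, and "the series" means these few. Any claim that something is new, unique, unknown or untested is made for them only; others in the source may bear on it.

Measured so far in an assay for inhibition of Fatty-acid amide hydrolase 1 (Rattus norvegicus); a lower number here means a stronger inhibitor, a higher number a weaker inhibitor:

compound 1 `O=C(CCCCC#Cc1cccc(Cl)c1Cl)c1ncc(-c2ccccn2)o1`: 5 nM
compound 2 `O=C(CCCCCCc1cccnc1)c1ncc(-c2ccccn2)o1`: 32 nM
compound 3 `O=C(O)c1ccc(CCCCCCC(=O)c2ncc(-c3ccccn3)o2)cc1`: > 600 nM, which is a limit of the assay and not a number.

Of the two numbers, compound 2 stands highest; compound 1 gives the lower number, and the gap between them lies beyond the scatter. Compound 3 sits at the limit of > 600 nM in this assay, at which 1 of the 3 values shown sits.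

The next compound is compound 4 `O=C(CCCCCSc1ccccc1)c1ncc(-c2ccccn2)o1`. Against compound 2 it differs by one group: phenylsulfanyl in place of (pyridin-3-yl)methyl on a saturated chain carbon, five bonds along the chain from a carbonyl carbon. Among the compounds with values here, only one measured step touches the same end of the chain: an at least 18-fold higher number from compound 2 to compound 3 (1.27 log units; beyond the scatter), where a 4-carboxyphenyl replaced the pyridin-3-yl. That step ran toward weaker inhibition and was large. Within the data shown here, the present change is of a different kind: an aromatic ring without a nitrogen enters and the carboxylic acid of compound 3 is absent, so the step of compound 3 sets no direct precedent. Compound 1 shows that a ring of carbon only, with halogens, sits at the strong end of the series, which argues against a loss. The expectation for compound 4 is therefore a step no larger than the scatter, if anything toward a lower number, with a 2.1-fold lower number from compound 2 to compound 4 (0.33 log units; beyond the scatter). Compound 4 is estimated at 15 nM, within 4 nM to 60 nM.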

Compound 4, inhibition constant: 3 nM
Beside the measured number, compound 4's estimate is 5.0-fold (0.70 log units) above it; measured number outside the range, below it.
By their numbers in this assay, from the lowest: compounds 4 and 1 (each within the scatter of the next); then compound 2. At a limit, above all of these: compound 3.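

In this assay, phenylsulfanyl in place of (pyridin-3-yl)methyl on a saturated chain carbon, five bonds along the chain from a carbonyl carbon, gives an 11-fold lower number from compound 2 to compound 4 (1.03 log units; beyond the scatter). A change at this end of the chain can therefore move the number down as well as up, a direction the earlier step from compound 2 did not show. Compound 4 at 3 nM and compound 1 at 5 nM lie within the scatter of each other, so two quite different chain ends on the shared core reach the same level, and nothing shown here gives a measured reason for the size of the new step.

Going by these compounds, the change replaces the ring nitrogen and brings in the sulfur in a single step, so the share of each stays open; a plain phenyl on an all-carbon chain, a phenoxy group or a pyridinylsulfanyl group would separate them. Also open, on these data alone, is how a carboxylic acid or an amine on the phenylsulfanyl ring, or a longer chain ahead of the sulfur, would read in this assay.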